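A few compounds are considered here, and "the series" means these few. Any claim that something is new, unique, unknown or untested is made for them only; others in the source may bear on it.

Measured compounds: compound 1 `COC(=O)C=CC(=O)c1sc(Nc2cccc(C)c2)nc1-c1ccncc1`, 2510 nM; compound 2 `Cc1ccc(Nc2nc(-c3ccncc3)cs2)cc1C`, 6610 nM.

In a functional assay on RCC4 cells (Homo sapiens) for inhibition, read by XTT assay, with a stated time of 4 days (on this read-out lower numbers stand for stronger inhibition and higher numbers for weaker inhibition), compound 1 holds the lowest of the two numbers; compound 2 stands beyond the scatter with the higher number. Compound 3 `Cc1cccc(Nc2nc(-c3ccncc3)c(C(N)=O)s2)c1` has not been measured yet. It differs from compound 1 in one place: amino in place of 2-(methoxycarbonyl)ethenyl on a carbonyl carbon. Going by the values given here, no measured pair shows a step of this kind, so the expectation rests on this change alone. A modest rise beyond the scatter is expected, a 2.2-fold higher number from compound 1 to compound 3 (0.34 log units; beyond the scatter). Compound 3 is thus estimated to give about 5500 nM, within a range from 1800 nM to 18000 nM.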

Compound 3, half-maximal inhibitory concentration: 19500 nM
Beside the measured number, compound 3's estimate is 3.5-fold (0.55 log units) below it; measured number above the stated range.
By their numbers in this assay, from the lowest: compound 1; then compound 2; then compound 3.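

In this assay, what this carbonyl carbon carries clearly matters: exchanging 2-(methoxycarbonyl)ethenyl for amino, which leaves a plain carbamoyl, gives a 7.8-fold higher number from compound 1 to compound 3 (0.89 log units; beyond the scatter). In this single pair, then, the longer chain goes with the stronger inhibition, the first reading available for this place. Nothing measured here explains the difference. Still open, from the compounds shown here alone, is which part of the departing chain counts, the ethenyl or the methoxycarbonyl end. Also open, going by these compounds, is how a carboxylic acid, or a longer chain ending in an amine, would read at the same carbonyl carbon.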